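Trimming an ethoxy to a methoxy on a HeLa inhibitor

The source may hold more compounds than are shown below. What is called first, only, known or untested is meant among the compounds shown, and "the series" means these compounds.

Measured compounds:
compound 1 `C=C(Br)C(=O)Nc1cccc(-c2cn3nc(-c4ccc(OCC)cc4)sc3n2)c1`: 1100 nM
compound 2 `COc1cccc(-c2nn3cc(-c4cccc(N)c4)nc3s2)c1`: 230000 nM
compound 3 `Nc1cccc(-c2cn3c(-c4ccccc4)csc3n2)c1`: 60000 nM

Of the compounds shown here, three sharing a related core have been tested in a functional assay on HeLa cells (Homo sapiens) for inhibition, read by cell counting, with a stated time of 4 days; on this read-out lower numbers stand for stronger inhibition and higher numbers for weaker inhibition. Among them compound 1 gives the lowest number, and both gaps to the other two lie beyond the usual scatter, so compound 1 is the most potent of the three in this assay. Compound 3 comes nearest to it, while compound 2 stands furthest away with the highest number.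

The next compound, compound 4 `C=C(Br)C(=O)Nc1cccc(-c2cn3nc(-c4ccc(OC)cc4)sc3n2)c1`, keeps everything in compound 1 except one small piece on the 4-ethoxyphenyl group: hydrogen in place of methyl on a saturated chain carbon bound to an oxygen on an aromatic ring. Put another way, ethoxy becomes methoxy, and no ring, donor, acceptor or charge is added or taken away.

Among the measured compounds shown here, no measured pair in this set differs by a change of this kind, so there is no direct precedent to lean on. A change this small, away from the bromoacrylamide that sets compound 1 apart from compounds 2 and 3, is expected to move the number little, if at all, beyond the scatter in this assay. The step from compound 1 is therefore estimated as a 1.1-fold higher number from compound 1 to compound 4 (0.04 log units; within the scatter). Compound 4 is expected to give about 1200 nM, within a range from 400 nM to 3500 nM.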

Compound 4, half-maximal inhibitory concentration: 2300 nM
Beside the measured number, compound 4's estimate is 1.9-fold (0.28 log units) below it; low and high end bracket the measured number.
By their numbers in this assay, from the lowest: compound 1; then compound 4; then compound 3; then compound 2.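

Read in this assay the trim from ethoxy to methoxy on the 4-ethoxyphenyl group gives a 2.1-fold higher number from compound 1 to compound 4 (0.32 log units; beyond the scatter) and so counts as a modest step, showing that this end of the molecule is not silent in the assay. Among the compounds shown here, removing one methyl adds or takes away no ring, donor, acceptor or charge, yet the number still moves beyond the usual scatter, something the earlier compounds could not show because no two of them differed in only one place. Nothing measured here explains why the number moves.

From the compounds shown here alone, with only ethoxy and methoxy to compare at this place, two compounds cannot establish a trend, so it remains open whether a longer chain such as propoxy, or a hydroxyl group in place of the ethoxy, would raise or lower the number. Going by these compounds, it is also open whether the same trim would have a similar effect on a compound that carries an amine, as compound 3 does, in place of the bromoacrylamide shared by compound 1 and compound 4.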